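Compound 2 to compound 4: one group exchanged

The source may hold more compounds than are shown below. What is called first, only, known or untested is meant among the compounds shown, and "the series" means these compounds.

In a functional assay on COR-L23 cells (Homo sapiens) for antiproliferative activity, read by CellTiter-Glo, with a stated time of 4 days (a higher number here means a weaker inhibitor, a lower number a stronger inhibitor), compound 1 `CC(=O)NCc1ncc2cc(COc3ccc(C(=O)NCc4cccnc4)cc3)n(CCC3CCCCC3)c2n1` gives 77 nM as its result. Compound 2 `O=C(NCc1cccnc1)Nc1ccc(CN2C(=O)c3ccccc3C2=O)cc1` has "not determined" (no result reported) as its entry in this assay and so stands on no number at all. Compound 3 `O=C(CCc1cccnc1)Nc1ccc(CN2C(=O)c3ccccc3C2=O)cc1` reads > 10000 nM there, which is a limit of the assay and not a number. Still without a result is compound 4 `O=C(/C=C/c1cccnc1)Nc1ccc(CN2C(=O)c3ccccc3C2=O)cc1`. The change is 2-(pyridin-3-yl)ethenyl in place of ((pyridin-3-yl)methyl)amino on a carbonyl carbon, with 2-(pyridin-3-yl)ethenyl in place of ((pyridin-3-yl)methyl)amino on a carbonyl carbon. Among the compounds with values here, no measured step sets its size, yet a large step towards stronger inhibition is expected, judged against compound 3 and its limit of > 10000 nM in this assay as the reference. In this assay compound 4 is estimated at 200 nM, with the expected range running from 15 nM to 3000 nM overall.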

Compound 4, half-maximal inhibitory concentration: 2000 nM
Estimate against measurement, compound 4: 10-fold (1.00 log units) below; low and high end bracket the measured number.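

In this assay, placing 2-(pyridin-3-yl)ethenyl instead of 2-(pyridin-3-yl)ethyl on the carbonyl carbon gives an at least 5.0-fold lower number from compound 3 to compound 4 (0.69 log units; beyond the scatter), so the double bond alone makes a measurable difference at this position. Compound 3 reads > 10000 nM, which is a limit of the assay and not a number. The step is therefore only a minimum, and its true size stays unknown: the limit of > 10000 nM in this assay, at which 1 of the 4 values shown sits.

Compound 2 has no result, and its step to compound 4 cannot be read. Going by these compounds, whether a carboxylic acid or a longer chain on this carbonyl carbon would keep the number of compound 4 stays open.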